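Working notes on cytotoxicity, compound 4 estimate

The compounds below may be only part of what the source reports. "The series", "measured", "known", "first", "only" and "open" are said of these compounds alone.

Measured in an ADME assay on HepG2 cells (Homo sapiens) for cytotoxicity, read by luminescence, CellTiter-Glo and ATP content, with a stated time of 72 h; a lower number here means that less compound is needed, a higher number that more compound is needed for the effect:
compound 1 `COc1cccc(CNCCCNc2ccnc3cc(Cc4ccccc4)ccc23)c1O`: 5720 nM
compound 2 `COc1cccc(CNCCCNc2ccnc3cc(-c4ccccc4)ccc23)c1O`: 3210 nM
compound 3 `COc1cccc(CNCCCNc2ccnc3cc(Cc4ccc(F)cc4)ccc23)c1O`: 4780 nM

Compound 1 gives the highest of the three numbers, but none of the others sits beyond the scatter from it. The step of a 1.8-fold lower number from compound 1 to compound 2 (0.25 log units; within the scatter) and the step of a 1.2-fold lower number from compound 1 to compound 3 (0.08 log units; within the scatter) are both small, as is a 1.5-fold higher number from compound 2 to compound 3 (0.17 log units; within the scatter); all three changes touch the group at the far end of the shared core and none of them moves this assay in a way that can be read as real.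

Compound 4 `COc1ccc(F)cc1CNCCCNc1ccnc2cc(Cc3ccccc3)ccc12` differs from compound 1 at the other end: 5-fluoro-2-methoxyphenyl in place of 2-hydroxy-3-methoxyphenyl on a saturated chain carbon bound to an amine nitrogen. Among the compounds with values here, no measured pair in the set alters this part of the molecule, so nothing here speaks directly to the change. What the set does show is that the three measured variations, whatever their nature, all stayed within the scatter of this assay, and the numbers cluster in a narrow band.

On that basis compound 4 is expected to land close to compound 1, with a step of a 1.1-fold lower number from compound 1 to compound 4 (0.06 log units; within the scatter) that is not expected to exceed the scatter. The estimate for compound 4 is 5000 nM, with a range from 2500 nM to 10000 nM.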

Compound 4, half-maximal effective concentration: 7990 nM
Compound 4: middle estimate off by 1.6-fold (0.20 log units), on the low side; the range from low to high includes it.
By their numbers in this assay, from the lowest: compounds 2, 3, 1 and 4 (each within the scatter of the next, the first and the last beyond it).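

In this assay this end of the molecule now has a reading of its own: a 1.4-fold higher number from compound 1 to compound 4 (0.15 log units; within the scatter), so 5-fluoro-2-methoxyphenyl in place of 2-hydroxy-3-methoxyphenyl, on a saturated chain carbon bound to an amine nitrogen, gives no change that can be read as real. The swap is not a small one on paper, since the group that leaves has 1 hydrogen-bond donor and 2 hydrogen-bond acceptors and the group that enters has 0 hydrogen-bond donors and 1 hydrogen-bond acceptor, yet this difference in counts comes with a step inside the scatter. No measurement at hand bears on what lies behind this step.

This single step changes the hydroxy, the methoxy placement and the fluoro together, so the compounds shown cannot separate their contributions, and a cancellation of opposing contributions cannot be ruled out. As far as these compounds go, whether a carboxylic acid or an amine on this ring, or a longer chain at this place, would also stay within the scatter of this assay remains open.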